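Chloro for methoxy on the shared core

The compounds below may be only part of what the source reports. "The series", "measured", "known", "first", "only" and "open" are said of these compounds alone.

Among the measured compounds shown here, compound 1 `COc1cccc2cc(C(=O)O)cnc12` is the only member of the set with a number in a functional assay on the whole organism (strain Sprague-Dawley) for inhibition, with Rattus norvegicus as the target; a higher number here means that more compound is needed for the effect, a lower number that less compound is needed: compound 1 gives 150 mg/kg. Compound 2 `COc1ccc(OC)c2ncc(C(=O)O)cc12` gives in this assay only a limit, > 50 mg/kg. The step that the limit leaves unreadable from compound 1 to compound 2 is left unreadable by the limit of > 50 mg/kg in this assay, at which 1 of the 2 values shown sits. Compound 3 `O=C(O)c1cnc2c(Cl)cccc2c1` differs from compound 1 by chloro in place of methoxy on an aromatic carbon. No measured step bears on this change; the single step shown concerns another change and has no readable size. For compound 3 in this assay no step beyond the scatter is expected in either direction, so compound 3 is estimated at 150 mg/kg (range 50 mg/kg to 400 mg/kg), which means an expected step of no change at the digits printed from compound 1 to compound 3 (within the scatter).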

Compound 3, minimum effective dose: 150 mg/kg
Compound 3: middle estimate and measured number agree at the digits printed; the range from low to high includes it.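

In this assay chloro in place of methoxy on an aromatic carbon, ortho to a fused ring, gives no change at the digits printed from compound 1 to compound 3 (within the scatter). Among the compounds shown here, this is the first readable step, and for this single pair the methoxy can be exchanged for chloro at this position without a step beyond the scatter. Nothing shown accounts for this result.

Going by these compounds, whether an amine or a longer alkoxy chain at this position would also leave the dose within the scatter stays open. Compound 2, with its further methoxy, gives only a limit, so its step cannot be read: the limit of > 50 mg/kg in this assay, at which 1 of the 3 values shown sits.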